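The source may report more compounds than this note shows. Statements on the series, on what has been measured and on what is new or still open speak of the compounds shown alone.

Three compounds have been measured in a functional assay on HEp-2 cells (Homo sapiens) for antiproliferative activity, read by MTT assay, with a stated time of 72 h; on this read-out lower numbers stand for stronger inhibition and higher numbers for weaker inhibition:
compound 1 `COc1ccc2occ(CSC(=S)N(C(C)C)C(C)C)c(=O)c2c1` gives 8900 nM;
compound 2 `Cc1ccc2c(=O)c(CSC(=S)N3CCCC3)coc2c1` gives 3600 nM;
compound 3 `COc1ccc2occ(CSC(=S)N3CCCC3)c(=O)c2c1` gives 3100 nM.

Compounds 2 and 3 carry the same thiocarbonyl-bearing side chain and differ in their cores; the difference between the two cores is not broken down here. Their values lie within the scatter of each other, so nothing separates them in this assay. Compound 1 differs from compound 3 in one place: diisopropylamino in place of pyrrolidin-1-yl on a thiocarbonyl carbon. This change gave a 2.9-fold higher number from compound 3 to compound 1 (0.46 log units; beyond the scatter).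

Compound 4 `Cc1ccc2c(=O)c(CSC(=S)N(C(C)C)C(C)C)coc2c1` has not yet been measured. It differs from compound 2 in exactly the same way: diisopropylamino in place of pyrrolidin-1-yl on a thiocarbonyl carbon. The place is the same in both pairs, a thiocarbonyl carbon whose other neighbour is sulfur, so this is the same change seen before, now on the core of compound 2. Going by the values given here, the only evidence for its effect is the one measured pair, and compound 2 and compound 3 sit within the scatter of each other, so the expectation is that the step from compound 2 to compound 4 is of similar size: a 2.8-fold higher number from compound 2 to compound 4 (0.44 log units; beyond the scatter). On that basis compound 4 is estimated at 10000 nM in this assay, with a likely range from 5000 nM to 22000 nM.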

Compound 4, half-maximal inhibitory concentration: 700 nM
For compound 4 the middle estimate is 14-fold (1.15 log units) above the measured one, outside the stated range (below it).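

In this assay, diisopropylamino in place of pyrrolidin-1-yl on a thiocarbonyl carbon gave a 5.1-fold lower number from compound 2 to compound 4 (0.71 log units; beyond the scatter). Set beside the earlier pair, the same change moves the numbers in opposite directions on the two cores: the same change on two cores in this assay, a 2.9-fold higher number (0.46 log units; beyond the scatter) from compound 3 to compound 1 and a 5.1-fold lower number (0.71 log units; beyond the scatter) from compound 2 to compound 4, 15-fold (1.17 log units) apart, beyond the scatter of two such steps So in this series, the effect measured for this change on one core could not be carried over to the other, but two pairs cannot show which feature of the cores lies behind the difference, nor predict the outcome on any further core.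

The compounds shown leave open whether other amine groups on the thiocarbonyl carbon, such as piperidin-1-yl, morpholin-4-yl or diethylamino, would follow the pattern of the core of compound 2 or that of the core of compound 3. They also leave open how the change would behave on a core carrying a different group, such as chloro, in place of the methyl group of compound 2 or the methoxy group of compound 3.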